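The source may report more compounds than this note shows. Statements on the series, on what has been measured and on what is new or still open speak of the compounds shown alone.

Measured so far:
compound 1 `Cc1cccc(-c2ccnc(C(=O)Nc3ccc(Oc4ccnc5[nH]ccc45)c(F)c3)c2)c1` gives 860 nM in a functional assay on PC-3 cells (Homo sapiens) for cytotoxicity, read by MTT assay, with a stated time of 72 h; a lower number here means a stronger inhibitor, a higher number a weaker inhibitor;
compound 2 `Cc1ccc(-c2ccnc(C(=O)Nc3ccc(Oc4ccnc5[nH]ccc45)c(F)c3)c2)cc1` gives 3970 nM in this assay.

Compound 2 stands highest of the two numbers in this assay; its nearest neighbour is compound 1, and the step of a 4.6-fold higher number from compound 1 to compound 2 (0.66 log units; beyond the scatter) lies beyond the scatter. Compound 3 `Cc1ccc(-c2ccnc(C(=O)Nc3ccc(Oc4ccnc5[nH]ccc45)c(F)c3)c2)c(C)c1` differs from compound 2 by methyl in place of hydrogen on an aromatic carbon. For the measured compounds named here, only the step of a 4.6-fold higher number from compound 1 to compound 2 (0.66 log units; beyond the scatter) bears on this, and loosely: that step moved a methyl rather than adding one, and no measured step adds a second methyl. The account therefore expects no step beyond the scatter from compound 2 to compound 3 in this assay, a 1.3-fold lower number from compound 2 to compound 3 (0.12 log units; within the scatter). Compound 3 is estimated at 3000 nM, within 900 nM to 10000 nM.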

Compound 3, half-maximal inhibitory concentration: 4010 nM
The estimate for compound 3 lay 1.3-fold (0.13 log units) below the measured number; low and high end bracket the measured number.
By their numbers in this assay, from the lowest: compound 1; then compounds 2 and 3 (each within the scatter of the next).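

In this assay, adding a methyl ortho to a large group, which turns the 4-methylphenyl of compound 2 into the 2,4-dimethylphenyl of compound 3, leaves the number unmoved (a 1.0-fold higher number from compound 2 to compound 3 (0.00 log units; within the scatter)). The added methyl does not close the gap to compound 1, as the listed step remains beyond the scatter (a 4.7-fold higher number from compound 1 to compound 3 (0.67 log units; beyond the scatter)). Nothing measured here accounts for either step. Open, from the compounds shown here alone, is whether an amine or a methoxy group in place of this methyl would move the number, and whether a second methyl on the 3-methylphenyl of compound 1 would do so.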